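This account rests on a few compounds, and the source may have more. Where it says the series, first, only, none or still open, it means among the compounds named here.

In an ADME assay on Vero cells (Chlorocebus sabaeus) for cytotoxicity, read by MTT assay, with a stated time of 72 h (a higher number here means that more compound is tolerated, a lower number that less compound is tolerated), compound 3, with the structure `COC(=O)c1cc(-c2cccc(NC(=O)c3ccc(/C=C/C(=O)c4ccc(F)cc4F)cc3)c2)on1`, reaches only a limit of the assay, > 40 ug/mL. Compound 1, with the structure `COC(=O)c1cc(-c2cccc(NC(=O)c3ccc(/C=C/C(=O)c4cccc(Br)c4)cc3)c2)on1`, likewise shows only a limit, > 100 ug/mL. Compound 2, with the structure `COC(=O)c1cc(-c2cccc(NC(=O)c3ccc(/C=C/C(=O)c4ccc(Cl)cc4)cc3)c2)on1`, also shows only a limit, > 50 ug/mL. Compound 4 has the structure `COC(=O)c1cc(-c2cccc(NC(=O)c3ccc(/C=C/C(=O)c4ccc(OC)c(OC)c4)cc3)c2)on1` and carries the change (3,4-dimethoxyphenyl in place of 2,4-difluorophenyl on a carbonyl carbon). The measured steps a step that the two limits leave unreadable from compound 1 to compound 2, a step that the two limits leave unreadable from compound 1 to compound 3 and a step that the two limits leave unreadable from compound 2 to compound 3 each exchange one substituted phenyl for another, and their size cannot be read because of the limit of > 100 ug/mL in this assay, at which 1 of the 3 values shown sits, the limit of > 50 ug/mL in this assay, at which 1 of the 3 values shown sits, and the limit of > 40 ug/mL in this assay, at which 1 of the 3 values shown sits, mark both ends of every pair. For the measured compounds named here, the move to the dimethoxyphenyl has no measured counterpart. Compound 4 is therefore expected to stay near its limit, with an estimated step that the limit leaves unreadable from compound 3 to compound 4. The estimated value for compound 4 is 80 ug/mL, between 35 ug/mL and 200 ug/mL.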

Compound 4, half-maximal cytotoxic concentration: > 50 ug/mL
Compound 4 gave a limit, no number (the forecaster's own chance of this, stated with the estimate: 70%); the middle value is on the limit's open side.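

For the compounds shown here, compound 1, compound 2, compound 3 and compound 4 all give only limits in this assay, and no step among them can be read. The compounds shown leave open whether exchanging one substituted phenyl for another on the carbonyl carbon changes the tolerated concentration at all.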